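Arylamino versus alkoxy at the enol carbon: series notes

This account rests on a few compounds, and the source may have more. Where it says the series, first, only, none or still open, it means among the compounds named here.

Measured so far:
Compound 1, `CCOC1=C(C(=O)c2ccccc2)C(c2ccc(Br)cc2)N(CCCn2ccnc2)C1=O`, gives 28900 nM in a functional assay on NCI-H1299 cells (Homo sapiens) for antiproliferative activity, read by MTT assay, with a stated time of 72 h; on this read-out lower numbers stand for stronger inhibition and higher numbers for weaker inhibition.
Compound 2, `CCCCCOC1=C(C(=O)c2ccccc2)C(c2ccc(Br)cc2)N(CCCn2ccnc2)C1=O`, gives 10300 nM.
Compound 3, `Cc1ccc(NC2=C(C(=O)c3ccccc3)C(c3ccc(Br)cc3)N(CCCn3ccnc3)C2=O)cc1`, gives 25800 nM.

Compound 2 holds the lowest number of the three measured, and both of its steps to the others lie beyond the scatter. Lengthening the alkoxy chain gave a 2.8-fold lower number from compound 1 to compound 2 (0.45 log units; beyond the scatter). Exchanging the ethoxy of compound 1 for the arylamino of compound 3 gave a 1.1-fold lower number from compound 1 to compound 3 (0.05 log units; within the scatter), a step within the scatter, whereas the exchange from the pentyloxy compound gave a 2.5-fold higher number from compound 2 to compound 3 (0.40 log units; beyond the scatter).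

Compound 4, `CCOc1ccc(NC2=C(C(=O)c3ccccc3)C(c3ccc(Br)cc3)N(CCCn3ccnc3)C2=O)cc1`, differs from compound 2 by (4-ethoxyphenyl)amino in place of pentyloxy on a double-bonded ring carbon. Among the compounds with values here, the step that bears on it is the one from compound 2 to compound 3, where a pentyloxy was likewise replaced by a para-substituted arylamino and the number rose modestly; the step from compound 1 to compound 3 adds that arylamino and ethoxy sit close together on this read-out. Nothing measured separates a methyl from an ethoxy on the aryl ring, so a step of similar size and direction is expected in this assay. This points to an expected step of a 2.3-fold higher number from compound 2 to compound 4 (0.37 log units; beyond the scatter). Compound 4 is thus estimated at 24000 nM, with a range from 9000 nM to 60000 nM.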

Compound 4, half-maximal inhibitory concentration: 20000 nM
Beside the measured number, compound 4's estimate is 1.2-fold (0.08 log units) above it, within the range that was stated.
By their numbers in this assay, from the lowest: compounds 2, 4, 3 and 1 (each within the scatter of the next, the first and the last beyond it).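

In this assay, the (4-ethoxyphenyl)amino group at this double-bonded ring carbon gives no step beyond the scatter against the pentyloxy compound (a 1.9-fold higher number from compound 2 to compound 4 (0.29 log units; within the scatter)), the methyl analogue (a 1.3-fold lower number from compound 3 to compound 4 (0.11 log units; within the scatter)) or the ethoxy compound (a 1.4-fold lower number from compound 1 to compound 4 (0.16 log units; within the scatter)). The modest separation seen between pentyloxy and (4-methylphenyl)amino therefore does not carry over to this second arylamino group, and the pentyloxy compound 2 no longer stands apart from every other compound in the series. Ethoxy in place of methyl on the aromatic carbon also makes no readable difference, so the two arylamino compounds sit together on this read-out, and no measurement shown here offers an explanation for these results.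

Still open, as far as these compounds go, is whether the step from ethoxy to pentyloxy at the ring carbon continues with a longer chain such as heptyloxy or decyloxy. Also open, from the compounds shown here alone, is whether an arylamino group carrying a carboxylic acid or a dimethylamino group on its aromatic ring would separate from the methyl and ethoxy analogues.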